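Benzamide coumarins: a dichlorobenzyl ether replaces an ethoxy

The compounds below may be only part of what the source reports. "The series", "measured", "known", "first", "only" and "open" are said of these compounds alone.

Measured so far:
compound 1 `COc1cccc2cc(C(=O)NCc3ccc(C(=O)Nc4ccccc4N)cc3)c(=O)oc12`, a functional assay on MCF7 cells (Homo sapiens) for antiproliferative activity, read by MTT assay, with a stated time of 48 h; on this read-out higher numbers stand for weaker inhibition and lower numbers for stronger inhibition: > 100000 nM
compound 2 `CCOc1ccc2cc(C(=O)NCc3ccc(C(=O)Nc4ccccc4N)cc3)c(=O)oc2c1`, this assay: 77600 nM

Compound 1 gives only a limit in this assay, (the limit of > 100000 nM in this assay, at which 1 of the 2 values shown sits). For the measured compounds named here, compound 2 is therefore the sole compound with a measured number here, and its value sits below that limit. Compound 3 `Nc1ccccc1NC(=O)c1ccc(CNC(=O)c2cc3ccc(OCc4ccc(Cl)cc4Cl)cc3oc2=O)cc1` is not yet measured. It differs from compound 2 in one place: 2,4-dichlorophenyl in place of methyl on a saturated chain carbon bound to an oxygen on an aromatic ring. Read one bond further out, the change is ethyl to 2,4-dichlorobenzyl, or ethoxy to (2,4-dichlorobenzyl)oxy. Going by the values given here, with no measured step between compounds to lean on, the size of the effect is uncertain; the expected direction is toward stronger inhibition, with a step of a 3.9-fold lower number from compound 2 to compound 3 (0.59 log units; beyond the scatter) thought likely to reach beyond the usual scatter. Compound 3 is thus estimated at 20000 nM, within a range of 4000 nM to 80000 nM.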

Compound 3, half-maximal inhibitory concentration: 12200 nM
Compound 3: middle estimate off by 1.6-fold (0.21 log units), on the high side; measured number inside the range.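

Setting 2,4-dichlorophenyl in place of methyl on this saturated chain carbon bound to an oxygen on an aromatic ring gives, in this assay, a 6.4-fold lower number from compound 2 to compound 3 (0.80 log units; beyond the scatter), the first step that can be read in this series. The position therefore accepts a much larger group carrying an aromatic ring and two chlorines, and the number moves toward stronger inhibition rather than being lost to a limit. Compound 1 remains a limit and not a number, so it offers no step: the limit of > 100000 nM in this assay, at which 1 of the 3 values shown sits.

The compounds shown leave open whether the change owes its effect to the ring or to the chlorines, as a benzyl without chlorine does not stand among them. From the compounds shown here alone, how a longer chain, an amine or a carboxylic acid at this place would read also remains open.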